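Swapping a chlorophenyl sulfonyl for methyl on the propanoic acid

This account rests on a few compounds, and the source may have more. Where it says the series, first, only, none or still open, it means among the compounds named here.

Compound 1 `CC(C)(C)c1ccc(CN(Cc2cccc(OCC(=O)O)c2)S(C)(=O)=O)cc1` and compound 2 `CC(C)(C)c1ccc(CN(Cc2cccc(CCC(=O)O)c2)S(=O)(=O)c2ccc(Cl)cc2)cc1` share a common core and differ in both the acid-bearing side chain and the group on the sulfonyl sulfur. In an assay on HEK293 cells for inhibition of prostaglandin E2 receptor EP2 subtype (Rattus norvegicus) (a higher number here means a weaker inhibitor, a lower number a stronger inhibitor), compound 1 gives 792 nM. For compound 2 this assay reports only a limit, > 3200 nM, so that one of the two values shown sits at the limit described in the limit of > 3200 nM in this assay, at which 1 of the 2 values shown sits. Compound 3 `CC(C)(C)c1ccc(CN(Cc2cccc(CCC(=O)O)c2)S(C)(=O)=O)cc1` keeps the propanoic acid of compound 2 and introduces the change (methyl in place of 4-chlorophenyl on a sulfonyl sulfur), methyl in place of 4-chlorophenyl on a sulfonyl sulfur. Among the measured compounds shown here, no measured pair shows this change directly; compound 1, which carries the same methylsulfonyl, gives 792 nM in this assay, so the expected step of an at least 2.1-fold lower number from compound 2 to compound 3 (0.32 log units; beyond the scatter) points toward stronger inhibition, beyond the scatter. Compound 3 is expected to give 1500 nM, within a range from 500 nM to 5000 nM.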

Compound 3, half-maximal inhibitory concentration: 379 nM
Compound 3: the middle estimate sits 4.0-fold (0.60 log units) above what was measured; measured number outside the range, below it.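

Methyl in place of 4-chlorophenyl on a sulfonyl sulfur, with the 2-carboxyethyl side chain unchanged, gives an at least 8.4-fold lower number from compound 2 to compound 3 (0.92 log units; beyond the scatter), so this change can now be read directly. The value of compound 2 is a limit and not a number: the limit of > 3200 nM in this assay, at which 1 of the 3 values shown sits. With the methylsulfonyl held fixed, 2-carboxyethyl in place of carboxymethoxy on an aromatic carbon gives a 2.1-fold lower number from compound 1 to compound 3 (0.32 log units; beyond the scatter), which shows that the side chain also moves the number, though by a modest step.

The compounds shown leave open how an unsubstituted phenyl, an ethyl or a trifluoromethyl on the sulfonyl sulfur would read in this assay. They also leave open how a longer chain or a tetrazole in place of the carboxylic acid would read, and whether the sulfonyl step holds with carboxymethoxy as the side chain.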